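Swapping cyclopentyl for propyl in compound 2

A few compounds are considered here, and "the series" means these few. Any claim that something is new, unique, unknown or untested is made for them only; others in the source may bear on it.

Compound 1 `CCCC(Oc1ccc(-n2cc(OC)cn2)cc1)c1ccc(C(=O)NCCC(=O)O)cc1` gives < 8 mL/min/kg as a limit of the assay
Compound 2 `O=C(O)CCNC(=O)c1ccc(C(Oc2ccc(-n3cc(C(F)(F)F)cn3)cc2)C2CCCC2)cc1` gives 22 mL/min/kg
Compound 3 `CCCC(Oc1ccc(-n2cc(C)cn2)cc1)c1ccc(C(=O)NCCC(=O)O)cc1` gives 16 mL/min/kg

In an ADME assay on microsomes from liver (Homo sapiens) for metabolic stability (a higher number here means faster removal of the compound, a lower number slower removal), compound 2 gives 22 mL/min/kg and compound 3 gives 16 mL/min/kg as its nearest number, and the two lie within the scatter of each other. Going by the values given here, compound 4 `CCCC(Oc1ccc(-n2cc(C(F)(F)F)cn2)cc1)c1ccc(C(=O)NCCC(=O)O)cc1` has propyl in place of cyclopentyl on a saturated chain carbon bound to an aromatic carbon and an oxygen on an aromatic ring as its only difference from compound 2. Among the compounds with values here, the one measured step (an at least 2.0-fold higher number from compound 1 to compound 3 (0.30 log units; that floor lies within the scatter)) is methyl in place of methoxy on an aromatic carbon, so it does not test this swap. Compound 3 also carries propyl and gives 16 mL/min/kg in this assay as the closest guide. The expected result is no change beyond the scatter, an estimated 1.3-fold lower number from compound 2 to compound 4 (0.11 log units; within the scatter) in this measurement. For compound 4 the estimate is 17 mL/min/kg within an expected range of 9 mL/min/kg to 32 mL/min/kg in this measurement.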

Compound 4, clearance: 16 mL/min/kg
Compound 4: the middle estimate sits 1.1-fold (0.03 log units) above what was measured; low and high end bracket the measured number.
By their numbers in this assay, from the lowest: compounds 3, 4 and 2 (each within the scatter of the next). At a limit, below all of these: compound 1.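

In this assay, a 1.4-fold lower number from compound 2 to compound 4 (0.14 log units; within the scatter), so propyl and cyclopentyl on this saturated chain carbon cannot be told apart here. With propyl held fixed, no change at the digits printed from compound 3 to compound 4 (within the scatter), so trifluoromethyl and methyl on the aromatic carbon cannot be told apart either. Set against methoxy, there is an at least 2.0-fold higher number from compound 1 to compound 4 (0.30 log units; that floor lies within the scatter), a step that can be read only as a floor: the limit of < 8 mL/min/kg in this assay, at which 1 of the 4 values shown sits.

As far as these compounds go, whether a longer chain or an amine on the saturated chain carbon would stay within the scatter remains open. So does what methoxy gives with cyclopentyl in place of propyl.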